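Swapping a fluoroethoxy side chain for chlorine on a pyridine

The source may report more compounds than this note shows. Statements on the series, on what has been measured and on what is new or still open speak of the compounds shown alone.

Compound 1 `Cn1ncc2c(-c3ccc(F)cc3)cc(NNC(=O)Nc3cc(Cl)nc(OCCF)c3)nc21`: 29300 nM
Compound 2 `Cn1nc(C(F)(F)F)c2c(-c3ccccc3)cc(NNC(=O)Nc3cc(Cl)nc(Cl)c3)nc21`: 13100 nM
Compound 3 `CCCOc1cc(NC(=O)NNc2cc(-c3ccc(OC)cc3)c3cnn(C)c3n2)cc(Cl)n1`: 37200 nM

All three were tested in a functional assay on SW620/5-FU cells (Homo sapiens) for cytotoxicity, read by MTT assay, with a stated time of 48 h, in the presence of a further agent that is not named here; a lower number here means that less compound is needed, a higher number that more compound is needed for the effect. Compound 1 gives the second highest of the three numbers; compound 3 lies within the usual scatter of it, while compound 2 sits beyond the scatter at a lower number. Compound 4 `Cn1ncc2c(-c3ccc(F)cc3)cc(NNC(=O)Nc3cc(Cl)nc(Cl)c3)nc21` has not been measured yet. It differs from compound 1 in one place: chloro in place of 2-fluoroethoxy on an aromatic carbon. Cut one bond further out, the change reads 2-chloro-6-(2-fluoroethoxy)pyridin-4-yl to 2,6-dichloropyridin-4-yl. Among the measured compounds shown here, no directly comparable pair is available, so the expected step of a 1.6-fold lower number from compound 1 to compound 4 (0.21 log units; within the scatter) is a modest move toward a lower number, possibly not beyond the scatter. Compound 4 is estimated at 18000 nM, with a range of 7000 nM to 45000 nM.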

Compound 4, half-maximal effective concentration: 9150 nM
The estimate for compound 4 lay 2.0-fold (0.29 log units) above the measured number; measured number inside the range.
By their numbers in this assay, from the lowest: compounds 4 and 2 (each within the scatter of the next); then compounds 1 and 3 (each within the scatter of the next).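

In this assay, putting chloro in place of 2-fluoroethoxy, next to the ring nitrogen, gives a 3.2-fold lower number from compound 1 to compound 4 (0.51 log units; beyond the scatter), a step beyond the scatter. Among the compounds shown here, this is the first pair here that differs in only one place, so the shift can be tied to this change alone: four heavy atoms leave and one chlorine enters. Nothing available explains why the number falls. Going by these compounds, how a methoxy group, an amine or a plain hydrogen would behave at this position remains open. So does whether the same swap would give a similar step on a different core.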